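The source may report more compounds than this note shows. Statements on the series, on what has been measured and on what is new or still open speak of the compounds shown alone.

Measured in a functional assay on MCF7 cells (Homo sapiens) for inhibition, read by MTT assay, with a stated time of 72 h; a higher number here means a weaker inhibitor, a lower number a stronger inhibitor:
- compound 1 `Cc1cc(Nc2cc(-c3ccccc3)[nH]n2)n2nc(SCc3cccc(Br)c3)nc2n1`: 5140 nM
- compound 2 `Cc1cc(Nc2cc(-c3ccccc3)[nH]n2)n2nc(SCCCc3ccccc3)nc2n1`: 3900 nM
- compound 3 `Cc1ccc(CSc2nc3nc(C)cc(Nc4cc(-c5ccccc5)[nH]n4)n3n2)cc1`: 7290 nM

Compound 3, at 7290 nM, cannot be separated from the other two compounds. Both a 1.4-fold higher number from compound 1 to compound 3 (0.15 log units; within the scatter) and a 1.9-fold higher number from compound 2 to compound 3 (0.27 log units; within the scatter) stay within the scatter, and so does a 1.3-fold lower number from compound 1 to compound 2 (0.12 log units; within the scatter).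

The next compound, compound 4 `Cc1cc(Nc2cc(-c3ccccc3)[nH]n2)n2nc(SCC3CC3)nc2n1`, carries a single change: cyclopropyl in place of 4-methylphenyl on a saturated chain carbon bound to a sulfur. In words, this is cyclopropyl in place of 4-methylphenyl on a saturated chain carbon bound to a sulfur.

All three measured steps were made at this same place, so they bear on the change, but only indirectly. Each exchanges one group containing a six-membered aromatic ring for another, and none shows what happens when such a ring leaves. Their small size gives no reason to expect a large move in this assay, although the data contain no direct precedent for cyclopropyl.

The expected step is a 1.2-fold higher number from compound 3 to compound 4 (0.09 log units; within the scatter), which means no change beyond the scatter is anticipated. For compound 4 the estimated value is 9000 nM, with an expected range of 3500 nM to 25000 nM.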

Compound 4, half-maximal inhibitory concentration: > 50000 nM
Compound 4: a limit, no number; the forecaster's own chance of this, stated with the estimate: 12%; middle value at least 5.5-fold (0.74 log units) from the limit.
By their numbers in this assay, from the lowest: compounds 2, 1 and 3 (each within the scatter of the next). At a limit, above all of these: compound 4.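

In this assay compound 4 gives only a limit, not a number: the limit of > 50000 nM in this assay, at which 1 of the 4 values shown sits. For the compounds shown here, the earlier compounds showed only that 3-bromophenyl, phenethyl and 4-methylphenyl cannot be told apart at this place; cyclopropyl is the first group there to separate from them, with an at least 6.8-fold higher number from compound 3 to compound 4 (0.83 log units; beyond the scatter), an at least 12-fold higher number from compound 2 to compound 4 (1.10 log units; beyond the scatter) and an at least 9.7-fold higher number from compound 1 to compound 4 (0.98 log units; beyond the scatter). All three steps lie beyond the scatter, so the group on a saturated chain carbon bound to a sulfur can matter in this assay, and the exchange of a six-membered aromatic ring for a three-membered non-aromatic ring gives a loss that swaps among the aromatic groups did not.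

The limit leaves the full size of these steps open. The compounds shown also cannot tell whether the aromatic ring or the count of heavy atoms matters, which a cyclohexyl group or a longer chain could address.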